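The source may hold more compounds than are shown below. What is called first, only, known or untested is meant among the compounds shown, and "the series" means these compounds.

Working notes, series in a functional assay on HT-29 cells (Homo sapiens) for inhibition; on this read-out lower numbers stand for stronger inhibition and higher numbers for weaker inhibition. Compound 1 `CC(=O)OC(C)n1cnc2c(Cl)nc(N)nc21` gives only a limit, > 500000 nM. Compound 2 `CC(=O)OCCOn1cnc2c(Cl)nc(N)nc21` likewise gives only a limit, > 500000 nM. Compound 3 `CC(=O)OC(C)n1cnc2c(S)nc(N)nc21` also gives only a limit, > 500000 nM. The change from compound 1 to compound 3 is sulfanyl in place of chloro on an aromatic carbon; the step it made is a step that the two limits leave unreadable from compound 1 to compound 3 because of the limit of > 500000 nM in this assay, at which 3 of the 3 values shown sit. How the core of compound 2 differs from the core of compound 1 is not broken down here. Compound 4 `CC(=O)OCCOn1cnc2c(S)nc(N)nc21` carries the same change relative to compound 2, (sulfanyl in place of chloro on an aromatic carbon), the place being described in identical words. For compound 4 the expected step of a number no higher from compound 2 to compound 4 (the limit leaves the size open) rests on (the limit of > 500000 nM in this assay, at which 3 of the 3 values shown sit), where compound 1 and compound 3 both sit. Compound 4 is estimated at 500000 nM, between 100000 nM and 5000000 nM, most probably reported again as a limit.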

Compound 4, half-maximal inhibitory concentration: > 500000 nM
Compound 4: no number, only a limit; the forecaster's own chance of this, stated with the estimate: 85%; the middle value lies on the limit itself.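

No step can be read from compound 2 to compound 4, since both give only a limit: the limit of > 500000 nM in this assay, at which 4 of the 4 values shown sit.

The compounds shown leave open whether sulfanyl in place of chloro changes inhibition at all, and how strong any of the four compounds is.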